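Tolerance notes: from compound 3 to compound 4

A few compounds are considered here, and "the series" means these few. Any claim that something is new, unique, unknown or untested is made for them only; others in the source may bear on it.

Measured in a toxicity assay on HepG2 2.2.15 cells (Homo sapiens) for cytotoxicity, read by CellTiter-Glo; a higher number here means that more compound is tolerated, a lower number that less compound is tolerated:
compound 1 `O=C1OC(c2ccccc2)CN1c1cnn2c1CN(C(=O)Nc1cc(F)c(F)c(F)c1)C(C1CC1)C2` gives 7410 nM
compound 2 `O=C1CC(c2cnco2)CN1c1cnn2c1CN(C(=O)Nc1cc(F)c(F)c(F)c1)C(C1CC1)C2` gives 139000 nM
compound 3 `O=C1c2ccccc2CN1c1cnn2c1CN(C(=O)Nc1cc(F)c(F)c(F)c1)C(C1CC1)C2` gives 38500 nM

Compound 3 stands in the middle of the three numbers, with compound 2 higher and compound 1 lower. Compound 4 `O=C(Nc1cc(F)c(F)c(F)c1)N1Cc2c(-c3ccc(F)cc3)cnn2CC1C1CC1` differs from compound 3 as follows: a group of 7 heavy atoms (6 carbon, 1 fluorine; one six-membered aromatic ring of carbon only) in place of a group of 10 heavy atoms (8 carbon, 1 nitrogen, 1 oxygen; one five-membered non-aromatic ring with 1 hetero atom, one six-membered aromatic ring of carbon only), on an aromatic carbon. All measured steps are swaps on this same aromatic carbon: a 5.2-fold higher number from compound 1 to compound 3 (0.72 log units; beyond the scatter), a 3.6-fold lower number from compound 2 to compound 3 (0.56 log units; beyond the scatter) and a 19-fold higher number from compound 1 to compound 2 (1.27 log units; beyond the scatter). For the measured compounds named here, the number therefore moves with this group, by modest to large steps, but no measured compound carries 4-fluorophenyl, so the direction is poorly supported. A modest step to a lower number is expected, as the expected step is a 2.6-fold lower number from compound 3 to compound 4 (0.41 log units; beyond the scatter). For compound 4 the estimated value is 15000 nM, with an expected range from 4000 nM to 55000 nM.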

Compound 4, half-maximal cytotoxic concentration: 38500 nM
Compound 4: middle estimate off by 2.6-fold (0.41 log units), on the low side; measured number inside the range.
By their numbers in this assay, from the lowest: compound 1; then compounds 3 and 4 (each within the scatter of the next); then compound 2.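

At this aromatic carbon, the five-membered non-aromatic ring of compound 3 is not required to hold the number, since 4-fluorophenyl, with 0 hydrogen-bond acceptors, leaves it in place (no change at the digits printed from compound 3 to compound 4 (within the scatter)). The same swap keeps the separation from the other two compounds (a 3.6-fold lower number from compound 2 to compound 4 (0.56 log units; beyond the scatter)) and (a 5.2-fold higher number from compound 1 to compound 4 (0.72 log units; beyond the scatter)), so a single aromatic ring suffices for the level seen with compound 3. No measurement available here accounts for these steps.

Open, on these data alone, is whether phenyl without the fluorine gives the same number as 4-fluorophenyl. Also open, as far as these compounds go, is how an amine or a carboxylic acid at this aromatic carbon would move it.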